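The source may report more compounds than this note shows. Statements on the series, on what has been measured and on what is new or still open speak of the compounds shown alone.

Measured so far:
Compound 1, `COc1cc2c(Oc3ccc(NC(=O)c4cc(-c5ccccc5F)ccn4)cc3F)ccnc2cc1OCCCN1CCCCC1`: 180 nM
Compound 2, `COc1cc2c(Oc3ccc(NC(=O)c4cc(-c5ccccc5C)ccn4)cc3F)ccnc2cc1OCCCN1CCCC1`: 440 nM

Both compounds were tested in a functional assay on MKN-45 cells (Homo sapiens) for cytotoxicity, read by MTT assay, with a stated time of 72 h; on this read-out higher numbers stand for weaker inhibition and lower numbers for stronger inhibition. Of the two, compound 2 stands at the higher number, which here means weaker inhibition; compound 1 sits lower, and the gap between them lies beyond the usual scatter. Compound 1 and compound 2 differ in two places at once, so no single structural step can be read off between them.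

Compound 3, `COc1cc2c(Oc3ccc(NC(=O)c4cc(-c5ccccc5F)ccn4)cc3F)ccnc2cc1OCCCN1CCCC1`, has not yet been measured. It is reached from compound 2 by one change: fluoro in place of methyl on an aromatic carbon. Compound 3 thereby shares its 2-fluorophenyl group with compound 1, but differs from compound 1 at the other end of the molecule. Among the compounds with values here, no measured pair isolates this change, so its effect on its own is unknown. Given that compound 1, which carries the fluoro group, gives 180 nM in this assay, a modest move toward a lower number is expected, though one that may stay within the scatter. The step from compound 2 to compound 3 is estimated as a 1.8-fold lower number from compound 2 to compound 3 (0.25 log units; within the scatter). For compound 3 the expected value is 250 nM, with a range from 110 nM to 550 nM.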

Compound 3, half-maximal inhibitory concentration: 230 nM
The estimate for compound 3 lay 1.1-fold (0.04 log units) above the measured number, and the stated range covers the measured number.
By their numbers in this assay, from the lowest: compounds 1, 3 and 2 (each within the scatter of the next, the first and the last beyond it).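

In this assay, within the data shown here, fluoro in place of methyl on an aromatic carbon, ortho to a large group, gives a 1.9-fold lower number from compound 2 to compound 3 (0.28 log units; within the scatter) and so can be read on its own for the first time, as a step that does not clear the usual scatter. Compound 3 also isolates the other difference, with pyrrolidin-1-yl in place of piperidin-1-yl at the end of the saturated chain giving a 1.3-fold higher number from compound 1 to compound 3 (0.11 log units; within the scatter) and likewise staying within the scatter. Neither single change is therefore firm by itself, even though compound 1 and compound 2, which differ in both places at once, lie beyond the scatter of each other.

Nothing measured here explains why either step has its size. Still open, from the compounds shown here alone, are what a chloro group, a methoxy group or a plain hydrogen would give at this place on the aromatic ring, whether morpholine at the end of the chain would fit with pyrrolidin-1-yl and piperidin-1-yl, and whether a 2-methylphenyl group paired with piperidin-1-yl would complete the picture.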